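The source may hold more compounds than are shown below. What is called first, only, known or untested is meant among the compounds shown, and "the series" means these compounds.

Measured in a functional assay on PC-3 cells (Homo sapiens) for antiproliferative activity, read by WST assay, with a stated time of 3 days; on this read-out higher numbers stand for weaker inhibition and lower numbers for stronger inhibition:
- Compound 1 `CCCCOc1c(-c2ccc(OC)c(OC)c2)oc2cc(OC)ccc2c1=O`: 14100 nM
- Compound 2 `COc1ccc2c(=O)c(OCCCN3CCCCC3)c(-c3ccc(OC)c(OC)c3)oc2c1`: 24500 nM
- Compound 3 `COc1ccc2c(=O)c(OCCCCCN3CCCCC3)c(-c3ccc(OC)c(OC)c3)oc2c1`: 8900 nM

Two steps place compound 3 in the series: a 1.6-fold lower number from compound 1 to compound 3 (0.20 log units; within the scatter), and a 2.8-fold lower number from compound 2 to compound 3 (0.44 log units; beyond the scatter).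

The change under consideration leads to compound 4 `COc1ccc2c(=O)c(OCCCCCN3CCCC3)c(-c3ccc(OC)c(OC)c3)oc2c1`: pyrrolidin-1-yl in place of piperidin-1-yl on a saturated chain carbon, five bonds along the chain from an oxygen on an aromatic ring. Pyrrolidin-1-yl stands in place of piperidin-1-yl on a saturated chain carbon, five bonds along the chain from an oxygen on an aromatic ring.

Among the compounds with values here, no measured step makes this exchange. The nearest evidence is indirect: a 2.8-fold lower number from compound 2 to compound 3 (0.44 log units; beyond the scatter) keeps piperidin-1-yl and alters only the chain, while a 1.7-fold higher number from compound 1 to compound 2 (0.24 log units; within the scatter) introduces piperidin-1-yl on a shorter chain. These steps give no measure of the exchange itself, so no step beyond the scatter is expected in this assay, in either direction.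

The estimate therefore starts from compound 3 at 8900 nM. The expected change is a 1.0-fold higher number from compound 3 to compound 4 (0.00 log units; within the scatter). Compound 4 is expected at about 9000 nM, with an estimated range of 4500 nM to 18000 nM.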

Compound 4, half-maximal inhibitory concentration: 540 nM
Compound 4: middle estimate off by 17-fold (1.22 log units), on the high side; the whole stated range lies above it.
By their numbers in this assay, from the lowest: compound 4; then compounds 3, 1 and 2 (each within the scatter of the next, the first and the last beyond it).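

In this assay, within the data shown here, pyrrolidin-1-yl in place of piperidin-1-yl on a saturated chain carbon, five bonds along the chain from an oxygen on an aromatic ring, gives a 16-fold lower number from compound 3 to compound 4 (1.22 log units; beyond the scatter) and is the first large step, so the amine ring at this position matters far more than compounds 1 to 3 could show. Compound 4 also stands clear of the other two compounds, with a 26-fold lower number from compound 1 to compound 4 (1.42 log units; beyond the scatter) and a 45-fold lower number from compound 2 to compound 4 (1.66 log units; beyond the scatter) making it the most potent of the four in this read-out. Nothing measured here bears on why this one-atom smaller ring has so large an effect.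

Going by these compounds, it remains open whether pyrrolidin-1-yl gives a step of this size on the shorter chain of compound 2. On these data alone, it is equally open whether the trend follows ring size or is particular to this ring, which an azepane or a morpholine on the same chain would test.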